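The source may report more compounds than this note shows. Statements on the series, on what has been measured and on what is new or still open speak of the compounds shown alone.

In an ADME assay on microsomes from liver (Homo sapiens) for metabolic stability, read by mass spectrometry, using NADPH, with a stated time of 60 min (on this read-out higher numbers stand for a more stable compound and lower numbers for a less stable compound), compound 1 `O=C(CNC1CC1c1cc(F)cc(F)c1OCc1cccnc1F)N1CCC2(CCNC2)CC1` gives 44%, while compound 2 `O=C(CNC1CC1c1cc(F)cc(F)c1OCc1cccnc1F)N1CCC(N2CC3CCC(C2)O3)CC1` gives 0%. Compound 1 therefore holds the higher of the two numbers, and the gap between them lies beyond the usual scatter. Compound 3 `O=C(CNC1CC1c1cc(F)cc(F)c1OCc1cccnc1F)N1CCC2(CCCN2)CC1` has the same atoms as compound 1, joined differently: a group of 10 heavy atoms (8 carbon, 2 nitrogen; one five-membered non-aromatic ring with 1 hetero atom, one six-membered non-aromatic ring with 1 hetero atom) in place of a group of 10 heavy atoms (8 carbon, 2 nitrogen; one five-membered non-aromatic ring with 1 hetero atom, one six-membered non-aromatic ring with 1 hetero atom), on a carbonyl carbon. The change sits on a carbonyl carbon, and the rest of the molecule stays as it is. Among the compounds with values here, no measured pair of compounds differs in this one place alone, so the expectation rests mainly on compound 1 and carries a wide range. What is expected in this assay is a number 4 percentage points lower from compound 1 to compound 3 (within the scatter), a small drop that stays within the scatter. The estimated result for compound 3 is 40%, with an expected range from 15% to 65%.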

Compound 3, percent of the compound remaining: 41%
The estimate for compound 3 lay 1 percentage points below the measured number; the range from low to high includes it.
By their numbers in this assay, from the lowest: compound 2; then compounds 3 and 1 (each within the scatter of the next).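

In this assay, within the data shown here, the first direct comparison at this position swaps one group for another with the same atoms and the same ring types, on a carbonyl carbon, and it gives a number 3 percentage points lower from compound 1 to compound 3 (within the scatter). On this read-out, then, how the atoms of these two groups are joined does not separate the two compounds, though this rests on a single pair. Nothing available here explains why the two groups give such similar results.

On these data alone, it remains open whether a group of another kind on this carbonyl carbon, such as an open-chain amine or a carboxylic acid, would give a similar result. This single pair also cannot show whether the same swap would behave alike on a different core.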